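Chloro in place of hydrogen on two related cores

The compounds below may be only part of what the source reports. "The series", "measured", "known", "first", "only" and "open" are said of these compounds alone.

Compound 1 `CCOC(=O)C1=C(C)N(c2ccccc2)C=CC1c1ccccc1` is the reference of the first pair; in a functional assay, tested at 100 ug/mL (a lower number here means a stronger effect, a higher number a weaker effect of the compound at the concentration tested), compound 1 gives -21.5%. Compound 2 `CCOC(=O)C1=C(C)N(c2ccc(Cl)cc2)C=CC1c1ccccc1` differs from it by chloro in place of hydrogen on an aromatic carbon and in this assay compound 2 gives -19.1%; the step is a number 2.4 percentage points higher from compound 1 to compound 2 (within the scatter), so the two values are not told apart.

Compound 3 `COC(=O)C1=C(C)N(c2ccccc2)C=C(C)C1c1ccccc1` carries a second core; the difference between the two cores is not broken down here. In this assay compound 3 gives -21.1%, close to compound 1 and compound 2.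

Compound 4 `COC(=O)C1=C(C)N(c2cccc(Cl)c2)C=C(C)C1c1ccccc1` stands to compound 3 as compound 2 to compound 1, by chloro in place of hydrogen on an aromatic carbon. The place is not the same: in compound 2 the chloro sits para to a large group, in compound 4 meta to a large group, so this is the same kind of change, not the same change.

Because the measured step was a number 2.4 percentage points higher from compound 1 to compound 2 (within the scatter), a small step is expected here as well, a number 2.1 percentage points higher from compound 3 to compound 4 (within the scatter). For compound 4 the expected value in this assay is -19%, between -31% and -7%.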

Compound 4, a percentage reported as activity, at one concentration (the size of the read-out at that concentration, not a potency): -21.3%
Beside the measured number, compound 4's estimate is 2.3 percentage points above it; the measured number falls inside the stated range.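

In this assay, chloro in place of hydrogen on the second core gives only a small step, a number 0.2 percentage points lower from compound 3 to compound 4 (within the scatter). Set beside the earlier step, the change reads alike on the two cores: the same change on two cores in this assay, a number 2.4 percentage points higher (within the scatter) from compound 1 to compound 2 and a number 0.2 percentage points lower (within the scatter) from compound 3 to compound 4, 2.6 percentage points apart, within the scatter of two such steps. For the compounds shown here, this shows only that the change gives no readable step on either core at this single concentration; with both steps within the scatter and the chloro in a different place in compound 2 and compound 4, it does not show that any effect carries from one core to the other, and it does not separate the role of the core from that of the place.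

The compounds shown leave open whether any group on this aromatic ring moves the read-out, as only hydrogen and chloro stand there. An amine or a carboxylic acid on that ring, or a longer chain on the ester, would test whether the values stay this close together.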